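Sulfated carbohydrate derivatives and their binding to fibroblast growth factor 1

The source may report more compounds than this note shows. Statements on the series, on what has been measured and on what is new or still open speak of the compounds shown alone.

Measured compounds:
Compound 1, `CCN(CC(=O)NC[C@H]1O[C@H](OC)[C@@H](OS(=O)(=O)O)[C@@H](OS(=O)(=O)O)[C@@H]1OS(=O)(=O)O)C(=O)COS(=O)(=O)O`: 174000 nM
Compound 2, `CO[C@H]1O[C@H](CNC(=O)CN(CCOS(=O)(=O)O)C(C)=O)[C@@H](OS(=O)(=O)O)[C@H](OS(=O)(=O)O)[C@@H]1OS(=O)(=O)O`: 95000 nM
Compound 3, `CCN(CC(=O)NC[C@H]1O[C@H](OC)[C@@H](OS(=O)(=O)O)[C@@H](OS(=O)(=O)O)[C@@H]1OS(=O)(=O)O)C(=O)CCCCCCCCCOS(=O)(=O)O`: 111000 nM

Three sulfated carbohydrate derivatives sharing the same core have been examined in an assay on isolated protein for binding affinity to fibroblast growth factor 1 (Homo sapiens), read by surface plasmon resonance; on this read-out higher numbers stand for weaker binding and lower numbers for tighter binding. Compound 2 gives the lowest number of the three, but its separation from the others is small: the step of a 1.8-fold lower number from compound 1 to compound 2 (0.26 log units; within the scatter) lies within the scatter, and the gap between compound 2 and compound 3 is smaller still, so no ordering among the three can be read from these numbers.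

Compound 4, `CO[C@H]1O[C@H](CNC(=O)CN(C(C)=O)c2ccccc2)[C@@H](OS(=O)(=O)O)[C@H](OS(=O)(=O)O)[C@@H]1OS(=O)(=O)O`, has not yet been measured in this assay. It differs from compound 2 in one place: phenyl in place of 2-(sulfooxy)ethyl on an amide-type nitrogen. Within the data shown here, no measured step alters the same position in the same way; the only measured step, from compound 1 to compound 2, exchanges a different set of groups on that amide-type nitrogen and stays within the scatter, and the pair compound 2 and compound 3 shows values within scatter of each other. Among the measured compounds shown here, there is thus no measured precedent for the effect of the entering phenyl.

On this basis compound 4 is expected to give about 130000 nM in this assay, with a range from 60000 nM to 300000 nM, corresponding to an expected step of a 1.4-fold higher number from compound 2 to compound 4 (0.14 log units; within the scatter).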

Compound 4, dissociation constant: 196000 nM
Estimate against measurement, compound 4: 1.5-fold (0.18 log units) below, within the range that was stated.
By their numbers in this assay, from the lowest: compounds 2, 3, 1 and 4 (each within the scatter of the next, the first and the last beyond it).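

In this assay, exchanging 2-(sulfooxy)ethyl for phenyl on the amide-type nitrogen gives a 2.1-fold higher number from compound 2 to compound 4 (0.31 log units; beyond the scatter), a modest step and the first in this set to lie beyond the scatter, so the group on this nitrogen can shift the number measurably. The shift does not follow the presence of a sulfooxy group in any simple way: compound 4 is the only one of the four with no sulfooxy group on its side chain, yet the exchange of ethyl(((sulfooxy)methyl)carbonyl)amino for acetyl(phenyl)amino gives a 1.1-fold higher number from compound 1 to compound 4 (0.05 log units; within the scatter), which stays within the scatter. No supporting evidence is available to explain the step from 2-(sulfooxy)ethyl to phenyl.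

Going by these compounds, it remains open whether the step follows the loss of the sulfooxy group or the arrival of the aromatic ring, a question that a plain ethyl or a benzyl group on the same nitrogen could separate. On these data alone, it is also open whether a carboxylic acid or an amine at the end of the two-carbon chain would give a number like that of compound 2 or that of compound 4.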